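From Hydroxyphenyl to Dichlorophenyl: Estimating Compound 4

The source may report more compounds than this note shows. Statements on the series, on what has been measured and on what is new or still open speak of the compounds shown alone.

Three measured compounds share one core and differ only in the aryl group attached to a carbon with a double bond to nitrogen. Compound 1 `COc1ccc(OC)c(/C=N/NC(=O)Nc2ccc(Oc3ccnc(-c4nncn4CCN(C)C)c3)c(F)c2)c1` carries a 2,5-dimethoxyphenyl there, and in a functional assay on NCI-H460 cells (Homo sapiens) for cytotoxicity, read by MTT assay, with a stated time of 72 h (on this read-out lower numbers stand for stronger inhibition and higher numbers for weaker inhibition), compound 1 gives 2930 nM. Compound 2 `CN(C)CCn1cnnc1-c1cc(Oc2ccc(NC(=O)N/N=C/c3cc(C(C)(C)C)cc(C(C)(C)C)c3O)cc2F)ccn1` gives 590 nM. Compound 3 `CN(C)CCn1cnnc1-c1cc(Oc2ccc(NC(=O)N/N=C/c3ccc(O)cc3)cc2F)ccn1`, with a 4-hydroxyphenyl, gives 1780 nM, the second highest of the three numbers; the step of a 1.6-fold lower number from compound 1 to compound 3 (0.22 log units; within the scatter) lies within the scatter, whereas the gap from compound 3 down to compound 2 lies beyond it.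

Compound 4 `CN(C)CCn1cnnc1-c1cc(Oc2ccc(NC(=O)N/N=C/c3c(Cl)cccc3Cl)cc2F)ccn1` is not yet measured. It differs from compound 3 by 2,6-dichlorophenyl in place of 4-hydroxyphenyl on a carbon with a double bond to nitrogen. For the measured compounds named here, the only measured step at this position, a 1.6-fold lower number from compound 1 to compound 3 (0.22 log units; within the scatter), was small, but compound 2 shows that the aryl group here can shift the number beyond the scatter. Going by the values given here, no measured step tests the loss of the hydrogen-bond donor and acceptor, so the direction is uncertain. A modest change is expected, a 1.5-fold lower number from compound 3 to compound 4 (0.17 log units; within the scatter). Compound 4 is therefore estimated at 1200 nM, within a range from 400 nM to 3600 nM.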

Compound 4, half-maximal inhibitory concentration: 350 nM
Compound 4: middle estimate off by 3.4-fold (0.54 log units), on the high side; the measured number lies below the stated range.
By their numbers in this assay, from the lowest: compounds 4 and 2 (each within the scatter of the next); then compounds 3 and 1 (each within the scatter of the next).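

At this position the aryl group matters in a way the first step did not show: in this assay the change to 2,6-dichlorophenyl gives a 5.1-fold lower number from compound 3 to compound 4 (0.71 log units; beyond the scatter) and also an 8.4-fold lower number from compound 1 to compound 4 (0.92 log units; beyond the scatter), both beyond the scatter. The entering group has no hydrogen-bond donors or acceptors, so a low number here does not depend on them, yet compound 2 keeps a hydroxyl group and gives 590 nM, so losing the hydroxyl is not required either. Nothing measured here explains these steps.

On these data alone, it remains open whether the chlorines or the loss of the hydroxyl carries the change; an unsubstituted phenyl or a phenyl with one chlorine would separate the two. Also open, as far as these compounds go, is how an aryl group bearing an amine or a carboxylic acid would behave here.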